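A few compounds are considered here, and "the series" means these few. Any claim that something is new, unique, unknown or untested is made for them only; others in the source may bear on it.

In an assay on isolated protein (Cricetulus griseus) for binding affinity to Alpha-1B adrenergic receptor (Mesocricetus auratus), read by radioligand binding (a higher number here means a weaker inhibitor, a lower number a stronger inhibitor), compound 1 `CCS(=O)(=O)Nc1cccc2c1CCCC2c1c[nH]cn1` gives 1320 nM. Compound 2 `CCS(=O)(=O)Nc1cccc2c1CCCC2CNC` is known in this assay only by a limit, < 10000 nM. Because of the limit of < 10000 nM in this assay, at which 1 of the 2 values shown sits, the step that the limit leaves unreadable from compound 1 to compound 2 cannot be sized, so compound 2 stands only as a limit, not as a number. Compound 3 `CCS(=O)(=O)Nc1cccc2c1CCCC2c1c[nH]c(C)n1` has not yet been measured in this assay. It differs from compound 2 by 2-methyl-1H-imidazol-4-yl in place of (methylamino)methyl on a saturated ring carbon. For the measured compounds named here, the single measured step, from compound 1 to compound 2, is unreadable, so no measured step gives a size for this change. What remains is that the group entering in compound 3 is the same kind of ring that compound 1 carries on the saturated ring carbon, differing only by the methyl in its name. Compound 3 is therefore expected near the value of compound 1, at an estimated 1500 nM within 400 nM to 6000 nM. The estimated step that the limit leaves unreadable from compound 2 to compound 3 is expected to point toward stronger binding, though its size cannot be read against a limit.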

Compound 3, inhibition constant: < 10000 nM
Compound 3 gave a limit, no number; the forecaster's own chance of this, stated with the estimate: 10%; the middle value is on the limit's open side.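

Neither compound 3 against compound 1 nor compound 3 against compound 2 gives a step that can be read, because each step runs into a limit: the limit of < 10000 nM in this assay, at which 2 of the 3 values shown sit. Still open, on these data alone, is whether methyl in place of hydrogen on an aromatic carbon changes binding at all, and how compound 2 and compound 3 rank.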